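This account rests on a few compounds, and the source may have more. Where it says the series, first, only, none or still open, it means among the compounds named here.

Working notes on the series. Three compounds share one core and differ only in the group on the left-hand ring. Compound 1 `O=c1c(-c2ccc(O)cc2)coc2cc(CC3OC(CO)C(O)C(O)C3O)ccc12` carries a sugar-like group joined through carbon and gives 0% in a functional assay on mitochondria (Cricetulus griseus) for inhibition of Monoamine oxidase (Homo sapiens), tested at 9 uM; on this read-out lower numbers stand for a weaker effect and higher numbers for a stronger effect at the one concentration tested. Compound 2 `O=c1c(-c2ccc(O)cc2)coc2cc(OCCCCBr)ccc12` carries a bromobutoxy chain and gives 98.3%. Compound 3 `O=c1c(-c2ccc(O)cc2)coc2cc(OCCC3OCCCO3)ccc12` carries the dioxane-bearing ether and gives 88.5%, the second highest of the three numbers; its nearest neighbour is compound 2 and its furthest is compound 1.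

Compound 4 `C=CCOc1ccc2c(=O)c(-c3ccc(O)cc3)coc2c1` is the next member and has not yet been measured. It differs from compound 3 as follows: a group of 2 heavy atoms (2 carbon; no ring) in place of a group of 7 heavy atoms (5 carbon, 2 oxygen; one six-membered non-aromatic ring with 2 hetero atoms), on a saturated chain carbon bound to an oxygen on an aromatic ring

Within the data shown here, only one measured step bears on this change, the exchange of one ether side chain for another: a number 9.8 percentage points lower from compound 2 to compound 3 (within the scatter). Both ether-bearing compounds sit high, while compound 1, which has no ether oxygen on the ring, sits at the bottom. Compound 4 keeps the ether oxygen and shortens the chain, so the expectation is for a number 3.5 percentage points lower from compound 3 to compound 4 (within the scatter), with no step beyond the scatter foreseen. For compound 4 the estimate is therefore 85%, with a range from 55% to 99%.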

Compound 4, a percentage reported as inhibition, at one concentration (the size of the read-out at that concentration, not a potency): 100%
Compound 4: middle estimate off by 15 percentage points, on the low side, outside the stated range (above it).
By their numbers in this assay, from the lowest: compound 1; then compounds 3, 2 and 4 (each within the scatter of the next, the first and the last beyond it).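

In this assay the exchange on a saturated chain carbon bound to an oxygen on an aromatic ring now gives a step that clears the scatter, a modest one: a number 11.5 percentage points higher from compound 3 to compound 4 (beyond the scatter) with vinyl entering and the group with the six-membered non-aromatic ring leaving. The ring-bearing group is therefore not needed at this place to keep the read-out high, and vinyl, with no ring and no hydrogen-bond acceptors, serves as well as 3-bromopropyl, as shown by a number 1.7 percentage points higher from compound 2 to compound 4 (within the scatter) and the fact that this step does not separate the two groups. No measurement on hand accounts for the rise from the ring-bearing group to vinyl, and its reason stays unknown.

The compounds shown leave open whether an amine or a carboxylic acid in place of vinyl would keep the read-out as high, and whether a longer chain carrying the same double bond would do so. With one tested concentration and readings this high, compound 2 and compound 4 also remain unranked in potency.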